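The source may report more compounds than this note shows. Statements on the series, on what has been measured and on what is new or still open speak of the compounds shown alone.

Within the data shown here, compound 1, `Cc1nn([C@H](C)c2ccc(Cl)cc2Cl)c2nc(N3CC[C@H](N4CCC[C@H]4C(N)=O)[C@H](C)C3)cnc12`, has in an assay on CCRF-CEM cells for antagonist activity at C-C chemokine receptor type 4 (Homo sapiens), read by CellTiter-Glo, with stated times of 30 min and 60 min, in the presence of a further agent that is not named here (a lower number here means a stronger inhibitor, a higher number a weaker inhibitor), the result "not determined" (no result reported), so the only number to stand on is that of compound 2, `Cc1nn([C@H](C)c2ccc(Cl)cc2Cl)c2nc(N3CC[C@H](N4CCCCC4)[C@H](C)C3)cnc12`, which in this assay gives 361 nM. Compound 3, `Cc1nn([C@H](C)c2ccc(Cl)cc2Cl)c2nc(N3CC[C@H](N4CCC[C@H]4CCC(N)=O)[C@H](C)C3)cnc12`, differs from compound 2 by 2-(2-carbamoylethyl)pyrrolidin-1-yl in place of piperidin-1-yl on a saturated ring carbon. Among the measured compounds shown here, no step between measured compounds is available to guide this change, so the expectation rests on compound 2 alone. The step of a 1.2-fold lower number from compound 2 to compound 3 (0.08 log units; within the scatter) is expected to stay within the usual scatter. Compound 3 is therefore estimated at 300 nM in this assay, with a likely range from 60 nM to 1500 nM.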

Compound 3, half-maximal inhibitory concentration: 355 nM
Beside the measured number, compound 3's estimate is 1.2-fold (0.07 log units) below it; the measured number falls inside the stated range.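

In this assay, the step of a 1.0-fold lower number from compound 2 to compound 3 (0.01 log units; within the scatter) shows that this saturated ring carbon tolerates a swap of piperidin-1-yl for the larger 2-(2-carbamoylethyl)pyrrolidin-1-yl with no readable loss of inhibition. A five-membered ring bearing a carbamoylethyl chain therefore reads level with the plain six-membered ring. Nothing available here accounts for this result.

From the compounds shown here alone, the step to compound 1, with its shorter chain, cannot be read, so the effect of chain length stays open. Going by these compounds, whether a carboxylic acid or an amine at the chain end would also be tolerated remains unknown.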